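Compound 2 to compound 4: benzyl gives way to phenyl

A few compounds are considered here, and "the series" means these few. Any claim that something is new, unique, unknown or untested is made for them only; others in the source may bear on it.

Compound 1 `O=C(CCCC(=O)Nc1ccc(NC(=O)Nc2ccc(Cl)c(C(F)(F)F)c2)cc1)NO`: > 10000 nM (a limit)
Compound 2 `O=C(Nc1ccc2c(c1)CCCN2Cc1ccc(C(=O)NO)cc1)Nc1ccc(Cl)c(C(F)(F)F)c1`: 3200 nM
Compound 3 `O=C(/C=C/c1ccc(NC(=O)Nc2ccc(Cl)c(C(F)(F)F)c2)cc1)NO`: 1900 nM

In a functional assay on PC-3 cells (Homo sapiens) for inhibition, read by sulforhodamine B assay, with a stated time of 48 h (on this read-out lower numbers stand for stronger inhibition and higher numbers for weaker inhibition), compound 2 gives 3200 nM and compound 3 gives 1900 nM, two values within the scatter of each other. Compound 1 reaches only a limit, > 10000 nM.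

Compound 4 `O=C(Nc1ccc2c(c1)CCCN2c1ccc(C(=O)NO)cc1)Nc1ccc(Cl)c(C(F)(F)F)c1` carries 4-(hydroxycarbamoyl)phenyl in place of 4-(hydroxycarbamoyl)benzyl on a nitrogen on an aromatic ring in a ring. Within the data shown here, the one measured step, an at least 5.2-fold lower number from compound 1 to compound 3 (0.72 log units; beyond the scatter), is a different change at a different place, so it bears only loosely on this one. Among the measured compounds shown here, with no measured step of this kind, the expectation rests on compound 2 at 3200 nM, and no shift beyond the scatter is expected: a 1.1-fold lower number from compound 2 to compound 4 (0.03 log units; within the scatter). For compound 4 the estimate is 3000 nM, with an expected range from 1000 nM to 9000 nM.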

Compound 4, half-maximal inhibitory concentration: 3000 nM
Estimate against measurement, compound 4: no gap at the digits printed, and the stated range covers the measured number.
By their numbers in this assay, from the lowest: compounds 3, 4 and 2 (each within the scatter of the next). At a limit, above all of these: compound 1.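

At this nitrogen, 4-(hydroxycarbamoyl)phenyl in place of 4-(hydroxycarbamoyl)benzyl gives a 1.1-fold lower number from compound 2 to compound 4 (0.03 log units; within the scatter). Among these compounds, this is the first step measured at this place, and on this read-out the two groups cannot be told apart. Nothing at hand accounts for this result.

The compounds shown leave open whether a longer chain between this nitrogen and the aromatic ring would move the number beyond the scatter. They also leave open what a carboxylic acid or a primary amide in place of the hydroxycarbamoyl group would do here.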